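A few compounds are considered here, and "the series" means these few. Any claim that something is new, unique, unknown or untested is made for them only; others in the source may bear on it.

Four compounds stand together here: compound 1 `COc1cc(OC)cc(N2CCN(C(=O)c3sc(C)nc3-c3ccccc3F)CC2)c1`, compound 2 `Cc1nc(-c2ccccc2)c(C(=O)N2CCN(c3ccc(C(F)(F)F)cc3)CC2)o1`, compound 3 `CC(C)(C)c1nc(-c2ccccc2F)c(C(=O)N2CCN(c3cccc(Cl)c3)CC2)o1` and the not yet measured compound 4 `Cc1ccc(C)c(N2CCN(C(=O)c3oc(C)nc3-c3ccccc3)CC2)c1`. Each was, or is to be, tested in a functional assay on HL-60 cells (Homo sapiens) for inhibition, read by MTT assay, with a stated time of 72 h; a lower number here means a stronger inhibitor, a higher number a weaker inhibitor. In this assay compound 1 gives 96.8 nM. For compound 2 this assay reports no number but only a limit, > 1000 nM. Compound 3 likewise returns only a limit, > 1000 nM. Compound 2 therefore sits at the limit of > 1000 nM in this assay, at which 2 of the 3 values shown sit, and only compound 1 yields a number that can be placed on the scale.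

No two of the measured compounds differ in just one place, so no step can be read from the measured numbers. Compound 4 differs from compound 2 in one place: 2,5-dimethylphenyl in place of 4-(trifluoromethyl)phenyl on an amine nitrogen in a ring.

Since compound 2 only sets a limit in this assay, the step to compound 4 cannot be anchored to a firm starting number. The step from compound 2 to compound 4 is expected to be a step that the limit leaves unreadable from compound 2 to compound 4, that is, no movement beyond the scatter, with a real chance that compound 4 again comes back as a limit. Compound 4 is estimated at 1500 nM, with a range from 400 nM to 6000 nM.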

Compound 4, half-maximal inhibitory concentration: 31.3 nM
Compound 4: middle estimate off by 48-fold (1.68 log units), on the high side; the whole stated range lies above it.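

The ring nitrogen that carries the aryl group proves to be a place where the choice of aryl group can decide the outcome: in this assay, putting 2,5-dimethylphenyl in place of 4-(trifluoromethyl)phenyl gives an at least 31-fold lower number from compound 2 to compound 4 (1.50 log units; beyond the scatter). Compound 2 returns only a limit, > 1000 nM. The earlier compounds could not show this, since no two of them differ in just one place, and the size of the new step is only a minimum because compound 2 stands at a limit rather than at a measured number: the limit of > 1000 nM in this assay, at which 2 of the 4 values shown sit.

This single pair cannot separate the effect of removing the trifluoromethyl group from that of adding the two methyl groups, nor say whether one methyl group alone would be enough. Also open, on these data alone, is how a phenyl ring carrying an amine or a carboxylic acid would behave at this place, and whether the same change would give a similar step on the core of compound 1 or compound 3.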